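Moving two fluorines on the phenyl of compound 3

The source may hold more compounds than are shown below. What is called first, only, known or untested is meant among the compounds shown, and "the series" means these compounds.

Compound 1 `CC[C@H](C)[C@H](N)CN(C(=O)[C@@H]1C[C@H]1c1ccccc1)c1ccc(-c2ccccc2)cc1`, 230 nM; 800 nM (2 entries)
Compound 2 `CC[C@H](C)[C@H](N)CN(C(=O)[C@@H]1C[C@H]1c1cccc(C)c1)c1ccc(-c2ccccc2)cc1`, 1200 nM
Compound 3 `CC[C@H](C)[C@H](N)CN(C(=O)[C@@H]1C[C@H]1c1cc(F)cc(F)c1)c1ccc(-c2ccccc2)cc1`, 960 nM

In a functional assay for agonist activity at G protein-coupled receptor 88 (Homo sapiens), read by HTRF and cAMP accumulation (on this read-out lower numbers stand for an effect already at smaller amounts and higher numbers for an effect only at larger amounts of compound), compound 3 holds the lowest of the two single numbers, but its neighbour compound 2 sits within the scatter, and the repeated entries of compound 1 the several entries of compound 1 in this assay, 230 nM; 800 nM (2 entries) show how wide that scatter can be. Compound 4 `CC[C@H](C)[C@H](N)CN(C(=O)[C@@H]1C[C@H]1c1c(F)cccc1F)c1ccc(-c2ccccc2)cc1` differs from compound 3 only by 2,6-difluorophenyl in place of 3,5-difluorophenyl on a saturated ring carbon. For the measured compounds named here, the one measured step on this ring, a 1.3-fold lower number from compound 2 to compound 3 (0.10 log units; within the scatter), stayed within the scatter, so a change of substituents on this phenyl has so far left the read-out essentially unmoved. No step beyond the scatter is therefore expected for compound 4 in this assay, and its value is estimated at 1200 nM, between 400 nM and 3500 nM, a step of a 1.3-fold higher number from compound 3 to compound 4 (0.10 log units; within the scatter).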

Compound 4, half-maximal effective concentration: 11000 nM
Estimate against measurement, compound 4: 9.2-fold (0.96 log units) below; the measured number lies above the stated range.
By their numbers in this assay, from the lowest: compounds 3 and 2 (each within the scatter of the next); then compound 4.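

In this assay, this phenyl turns out not to be indifferent to change: with the same atoms in the group, 2,6-difluorophenyl in place of 3,5-difluorophenyl gives an 11-fold higher number from compound 3 to compound 4 (1.06 log units; beyond the scatter), and replacing 3-methylphenyl with 2,6-difluorophenyl gives a 9.2-fold higher number from compound 2 to compound 4 (0.96 log units; beyond the scatter). So where the fluorines sit on this ring matters, not only which atoms are present. Both steps are wider than the spread between repeated readings: the several entries of compound 1 in this assay, 230 nM; 800 nM (2 entries)

Open, on these data alone, is whether a single fluorine would give the same rise, and whether chlorine or methoxy in those same places would do so too.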